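The source may hold more compounds than are shown below. What is called first, only, known or untested is meant among the compounds shown, and "the series" means these compounds.

Compound 1 `Cc1ccc(CN(C)C(=O)c2nn(-c3ccc(F)cc3)c(OC[C@@H](O)C[C@@H](O)CC(=O)O)c2C(C)C)cc1` — in an assay on microsomes from liver for inhibition of 3-hydroxy-3-methylglutaryl-coenzyme A reductase (Rattus norvegicus) (on this read-out lower numbers stand for stronger inhibition and higher numbers for weaker inhibition), compound 1 gives 37 nM.
Compound 2 `CC(C)c1c(C(=O)N(C)Cc2cccc(Cl)c2)nn(-c2ccc(F)cc2)c1OC[C@@H](O)C[C@@H](O)CC(=O)O` — in this assay compound 2 gives 8.3 nM.

Compound 2 stands lowest of the two numbers; its nearest neighbour is compound 1, and the step of a 4.5-fold lower number from compound 1 to compound 2 (0.65 log units; beyond the scatter) separates them. Compound 3 `CC(C)c1c(C(=O)N(C)Cc2ccc(F)c(F)c2)nn(-c2ccc(F)cc2)c1OC[C@@H](O)C[C@@H](O)CC(=O)O` has not yet been measured. It differs from compound 2 in one place: 3,4-difluorophenyl in place of 3-chlorophenyl on a saturated chain carbon bound to an amide-type nitrogen. Going by the values given here, the only measured step, a 4.5-fold lower number from compound 1 to compound 2 (0.65 log units; beyond the scatter), exchanges a 4-methylphenyl for a 3-chlorophenyl at the same saturated chain carbon bound to an amide-type nitrogen, so it shows that this part of the structure can move the number beyond the scatter, but it does not compare one halogenated ring with another. Among the compounds with values here, no step bears directly on the 3-chlorophenyl to 3,4-difluorophenyl exchange. Compound 3 is therefore expected to stay close to compound 2, with a 1.3-fold higher number from compound 2 to compound 3 (0.12 log units; within the scatter) as the expected step in this assay, within or near the scatter. The estimate for compound 3 in this assay is 11 nM, between 4 nM and 30 nM.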

Compound 3, half-maximal inhibitory concentration: 5.7 nM
Compound 3: middle estimate off by 1.9-fold (0.29 log units), on the high side, and the stated range covers the measured number.
By their numbers in this assay, from the lowest: compounds 3 and 2 (each within the scatter of the next); then compound 1.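

In this assay, 3,4-difluorophenyl in place of 3-chlorophenyl on the saturated chain carbon bound to an amide-type nitrogen gives a 1.5-fold lower number from compound 2 to compound 3 (0.16 log units; within the scatter), so these two halogenated rings cannot be told apart here. The 4-methylphenyl ring now stands apart from two halogenated rings rather than one, with a 6.5-fold lower number from compound 1 to compound 3 (0.81 log units; beyond the scatter), and no compound shown goes against that division. Nothing shown offers an explanation for why the two halogenated rings read alike or why the 4-methylphenyl ring reads differently.

On these data alone, it remains open how an unsubstituted phenyl, a 3-fluorophenyl or a 4-chlorophenyl would read at this position, and so which ring substituent carries the difference from the 4-methylphenyl ring. Also open, as far as these compounds go, is whether a pyridine ring or a methoxy-bearing phenyl would stay with the halogenated rings.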